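Chain variation on a shared core: gastric inhibition

A few compounds are considered here, and "the series" means these few. Any claim that something is new, unique, unknown or untested is made for them only; others in the source may bear on it.

Among the measured compounds shown here, the three measured members share one core and differ only in the saturated chain attached to it. Compound 1 `Cc1ccc(=O)n(CC(=N)S)n1` gives 31.5% in a functional assay on the whole organism (stomach) for inhibition, with Rattus norvegicus as the target, at a dose of 100 mg/kg by the intraduodenal route; a higher number here means more inhibition at the dose given (going by the name of the read-out), a lower number less inhibition. Compound 2 `Cc1ccc(=O)n(CCCC(=N)S)n1` gives 36.3% in this assay. Compound 3 `Cc1ccc(=O)n(CC(C)C(=N)S)n1` gives 30.2% in this assay. On these numbers compound 3 holds the lowest value of the three, yet its nearest neighbour compound 1 sits only slightly higher and the furthest, compound 2, is also within the scatter, so the three are not separated.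

Compound 4 `Cc1ccc(=O)n(CCC(=N)S)n1` is the unmeasured member. Its difference from compound 3 is hydrogen in place of methyl on a saturated chain carbon bound to a carbon with a double bond to nitrogen and a saturated chain carbon. For the measured compounds named here, no pair of measured compounds differing in one place is available, so the step can only be judged from the spread of the three values, which shows that chain changes of this kind have so far left the read-out within the scatter. The step from compound 3 to compound 4 is therefore expected to be none beyond the scatter, a number 2.8 percentage points higher from compound 3 to compound 4 (within the scatter). Compound 4 is expected to give 33% in this assay, with a range from 22% to 45%.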

Compound 4, a percentage reported as inhibition, in the whole organism at one dose (the size of the read-out at that dose, not a potency): 73.9%
Estimate against measurement, compound 4: 40.9 percentage points below; measured number above the stated range.
By their numbers in this assay, from the lowest: compounds 3, 1 and 2 (each within the scatter of the next); then compound 4.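

In this assay hydrogen in place of methyl on a saturated chain carbon bound to a carbon with a double bond to nitrogen and a saturated chain carbon gives a number 43.7 percentage points higher from compound 3 to compound 4 (beyond the scatter) and so shows that this position responds strongly to a single methyl, which the earlier values gave no sign of. The chain itself also matters, with a number 42.4 percentage points higher from compound 1 to compound 4 (beyond the scatter) on going from the shorter chain and a number 37.6 percentage points higher from compound 2 to compound 4 (beyond the scatter) on going from the longer one, so the read-out does not rise or fall steadily with chain length across these compounds. No measurement at hand bears on the cause of these steps.

Still open, going by these compounds, is whether a chain longer than that of compound 2 would stay low. On these data alone, it is equally open whether an amine or a carboxylic acid at the chain end would keep the high read-out of compound 4.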